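Swapping the Aryl Group on a Sulfonamide Sulfur

This account rests on a few compounds, and the source may have more. Where it says the series, first, only, none or still open, it means among the compounds named here.

Of the compounds shown here, three that share one core have been measured in an assay on HEK293 cells for displacement of a labelled ligand from 5-hydroxytryptamine receptor 6 (Homo sapiens), with a stated time of 60 min, tested at 0.01 uM, in the presence of a further agent that is not named here; on this read-out lower numbers stand for a weaker effect and higher numbers for a stronger effect at the one concentration tested. Compound 1 `COc1cc(N)c(Cl)cc1C(=O)CCC1CCN(CCNS(=O)(=O)c2cc(Br)ccc2Br)CC1` gives 16%. Compound 2 `COc1cc(N)c(Cl)cc1C(=O)CCC1CCN(CCNS(=O)(=O)c2ccc3c(c2)NC(=O)CO3)CC1` is reported as "not active" (no number reported), with no number attached. Compound 3 `COc1ccc(S(=O)(=O)NCCN2CCC(CCC(=O)c3cc(Cl)c(N)cc3OC)CC2)cc1OC` gives 3%, which is the lowest of the two numbers available, and the nearest number belongs to compound 1. Among the measured compounds shown here, the single step with a number, a number 13 percentage points lower from compound 1 to compound 3 (beyond the scatter), shows that exchanging the aryl group on the sulfonyl sulfur can move the read-out by a modest amount, here downward.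

Compound 4 `COc1cc(N)c(Cl)cc1C(=O)CCC1CCN(CCNS(=O)(=O)c2ccc(N)cc2)CC1` differs from compound 3 in just that place: 4-aminophenyl in place of 3,4-dimethoxyphenyl on a sulfonyl sulfur. For the measured compounds named here, no measured step covers a 4-aminophenyl group, so the only guide is that the aryl group on the sulfonyl sulfur has so far given either a small number or none at all. Compound 4 is therefore expected to stay near the bottom of this range, with an estimated step of a number 3 percentage points higher from compound 3 to compound 4 (within the scatter) in this assay that is unlikely to reach beyond the scatter. The estimate for compound 4 is 6%, expected to fall between 0% and 20%.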

Compound 4, a percentage reported as inhibition, at one concentration (the size of the read-out at that concentration, not a potency): 7%
Compound 4: middle estimate off by 1 percentage points, on the low side; measured number inside the range.
By their numbers in this assay, from the lowest: compounds 3, 4 and 1 (each within the scatter of the next, the first and the last beyond it).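

In this assay, exchanging the 3,4-dimethoxyphenyl group on the sulfonyl sulfur for 4-aminophenyl brings in a smaller group with a hydrogen-bond donor where there was none, yet the two compounds cannot be told apart (a number 4 percentage points higher from compound 3 to compound 4 (within the scatter)). Compound 4 also cannot be separated from the dibromo compound (a number 9 percentage points lower from compound 1 to compound 4 (within the scatter)), so it lies within the scatter of both compounds, even though those two lie beyond the scatter of each other; the earlier gap therefore does not divide this position into two clear classes of aryl group. Nothing available explains why this exchange leaves the read-out within the scatter.

As far as these compounds go, all three aryl groups with a number are substituted phenyl rings on the sulfonyl sulfur, so it remains open whether a carboxylic acid on that ring, or a plain methyl group in place of the ring, would move the read-out clear of the scatter. These numbers also come from a single concentration, so they leave open how the compounds would compare as potencies, and compound 2 can join that comparison only once it has a number.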